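The source may report more compounds than this note shows. Statements on the series, on what has been measured and on what is new or still open speak of the compounds shown alone.

For the measured compounds named here, compound 1 `CCCCc1nc(N)c2nc(O)n(Cc3ccccc3)c2n1` stands at the lower of the two numbers measured so far in a functional assay (spleen, spleen) for activation, with Mus musculus as the target; a higher number here means that more compound is needed for the effect, a lower number that less compound is needed: in this assay compound 1 gives 0.03 uM. The other measured compound, compound 2 `Nc1ncnc2c1nc(O)n2Cc1cccc2ccccc12`, gives in this assay a value of 10 uM, a far higher number than that of compound 1 and well beyond the scatter; the two compounds differ in more than one place, however, so no single change can be read from that pair.

Compound 3 `Nc1nc(N)c2nc(O)n(Cc3ccccc3)c2n1` has not yet been measured. It keeps the core of compound 1 and differs from it in one spot: amino in place of butyl on an aromatic carbon. The butyl goes and an amino group stands in its place on an aromatic carbon between two ring nitrogen atoms.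

Going by the values given here, no measured pair isolates this change. Compound 2, which also carries no butyl, gives 10 uM, and on that basis a rise in the number is expected: the step of a 100-fold higher number from compound 1 to compound 3 (2.00 log units; beyond the scatter) is estimated to lie beyond the scatter. For compound 3 the expected value in this assay is 3 uM, within a range from 0.3 uM to 30 uM.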

Compound 3, minimum effective concentration: 10 uM
Beside the measured number, compound 3's estimate is 3.3-fold (0.52 log units) below it, within the range that was stated.
By their numbers in this assay, from the lowest: compound 1; then compounds 2 and 3 (each within the scatter of the next).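

For the compounds shown here, the pair of compound 1 and compound 3 is the first to isolate the group on the aromatic carbon between two ring nitrogen atoms, with the rest of the core of compound 1 unchanged. In this assay the exchange of butyl for amino gives a 330-fold higher number from compound 1 to compound 3 (2.52 log units; beyond the scatter) and so lies beyond the scatter, which shows that the number depends strongly on the group at this position. In this pair, far less compound is needed for the effect with butyl than with amino, but nothing shown here accounts for the size of the step.

The compounds shown leave open whether the number follows the length of the chain at this position, as only butyl and amino stand there, and methyl, propyl or pentyl would show how it moves across a series of chains. They also leave open whether the chain itself or the absence of the amino group matters more, a question that butylamino or butoxy, each keeping a chain of the same kind but joining it through nitrogen or oxygen, could help to settle.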